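This account rests on a few compounds, and the source may have more. Where it says the series, first, only, none or still open, it means among the compounds named here.

Compound 1 `CC(C)(CCC/C=C(\c1ccccc1)c1cccnc1)C(=O)O` gives the lowest of the three numbers recorded in an assay (Equus caballus) for inhibition of Thromboxane-A synthase (Homo sapiens), using microsomes (a higher number here means a weaker inhibitor, a lower number a stronger inhibitor), where compound 1 reaches 21 nM. Compound 2 `CC(C)(CCC/C=C(/c1ccccc1)c1cccnc1)C(=O)O` returns 30 nM in this assay, and a 1.4-fold higher number from compound 1 to compound 2 (0.15 log units; within the scatter), a difference that rests on (the fact that compounds 1 and 2 differ only in the configuration as drawn). Compound 3 `O=C(O)CCCC/C=C(/c1ccc(F)cc1)c1cccnc1` gives 83 nM in this assay, but it differs from compound 1 in more than one place, so only the two values themselves can be compared. Compound 4 `C=CCC(CCC/C=C(\c1ccccc1)c1cccnc1)C(=O)O` carries 1-carboxybut-3-en-1-yl in place of 1-carboxy-1-methylethyl on a saturated chain carbon, three bonds along the chain from a double-bonded chain carbon. Within the data shown here, no measured step covers this change; the one step recorded lay within the scatter and concerns only the drawn configuration. The step is therefore expected to be a 1.7-fold higher number from compound 1 to compound 4 (0.22 log units; within the scatter). Compound 4 is estimated at 35 nM in this assay, ranging from 10 nM to 120 nM.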

Compound 4, half-maximal inhibitory concentration: 50 nM
Beside the measured number, compound 4's estimate is 1.4-fold (0.15 log units) below it; measured number inside the range.
By their numbers in this assay, from the lowest: compounds 1, 2, 4 and 3 (each within the scatter of the next, the first and the last beyond it).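

In this assay, the change to 1-carboxybut-3-en-1-yl on this saturated chain carbon gives a 2.4-fold higher number from compound 1 to compound 4 (0.38 log units; beyond the scatter), a modest step. Among these compounds, it is the first single-place change to move the number beyond the scatter, and it shows that the position is sensitive to this replacement, though not sharply so. Nothing recorded accounts for this step. The compounds shown leave open whether the double bond of the new group matters, which a saturated propyl group on the same carbon would test. They also leave open how a single methyl group or a longer chain would behave there.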